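The source may report more compounds than this note shows. Statements on the series, on what has been measured and on what is new or still open speak of the compounds shown alone.

- Compound 1: `CC(C)Oc1ccccc1CNC(=O)c1ccc2cncc(Cl)c2n1`, 6 ug/mL
- Compound 2: `Cc1cncc2ccc(C(=O)NCc3ccccc3OC(C)C)nc12`, 3 ug/mL

In a functional assay on Hs68 cells (Homo sapiens) for cytotoxicity (on this read-out higher numbers stand for lower toxicity in this test and lower numbers for higher toxicity in this test), compound 2 gives 3 ug/mL and compound 1 gives 6 ug/mL. Within the data shown here, these two values lie within the scatter of each other, so compound 2 does not stand apart on the numbers so far. Compound 3 (`CC(C)Oc1ccccc1CNC(=O)c1ccc2cnccc2n1`) has not yet been measured. It departs from compound 2 as follows: hydrogen in place of methyl on an aromatic carbon. In words, this is hydrogen in place of methyl on an aromatic carbon. Among the measured compounds shown here, only one measured step bears on this change: a 2.0-fold lower number from compound 1 to compound 2 (0.30 log units; within the scatter), with methyl in place of chloro on that same aromatic carbon. For the measured compounds named here, no measured step shows a compound with hydrogen there. With that single exchange inside the scatter, no step beyond the scatter is expected in this assay, in either direction. The estimate amounts to an expected 1.3-fold higher number from compound 2 to compound 3 (0.12 log units; within the scatter). Compound 3 is expected at 4 ug/mL, within an estimated range of 2 ug/mL to 9 ug/mL.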

Compound 3, half-maximal cytotoxic concentration: 2.5 ug/mL
Beside the measured number, compound 3's estimate is 1.6-fold (0.20 log units) above it, and the stated range covers the measured number.
By their numbers in this assay, from the lowest: compounds 3, 2 and 1 (each within the scatter of the next, the first and the last beyond it).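

In this assay, hydrogen in place of methyl gives a 1.2-fold lower number from compound 2 to compound 3 (0.08 log units; within the scatter) and so hydrogen and methyl on this aromatic carbon cannot be told apart. Among these compounds, the exchange of hydrogen for chloro gives a 2.4-fold lower number from compound 1 to compound 3 (0.38 log units; beyond the scatter) and is the first modest step at this position, one that the earlier exchange of methyl for chloro did not reach. Nothing given here accounts for either step.

On these data alone, whether an amine, a methoxy group or a nitrile on this same carbon would fall with hydrogen and methyl or with chloro stays open. As far as these compounds go, all three compounds share the rest of their structure, so it is also open whether the step from chloro to hydrogen would hold with another group on the amide nitrogen.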